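A few compounds are considered here, and "the series" means these few. Any claim that something is new, unique, unknown or untested is made for them only; others in the source may bear on it.

Measured so far in a physicochemical assay for solubility, read by HPLC, using the shake flask method, with a stated time of 2 h, at pH 2; on this read-out higher numbers stand for higher solubility and lower numbers for lower solubility:

compound 1, `Nc1ncc(-c2ccc(C(=O)N3CC(O)C3)cc2)nc1-c1ccc(C(F)(F)F)cc1`, 110000 nM
compound 2, `Nc1ncc(-c2ccc(C(=O)N3CCC(N)CC3)cc2)nc1-c1ccc(C(F)(F)F)cc1`, 200000 nM
compound 3, `Nc1ncc(-c2ccc(C(=O)O)cc2)nc1-c1ccc(C(F)(F)F)cc1`, a limit at < 5000 nM

Compound 1 gives the lowest of the two numbers in this assay, with compound 2 nearest; that pair lies within the scatter, as a 1.8-fold higher number from compound 1 to compound 2 (0.26 log units; within the scatter) shows. The value of compound 3 is a limit of this assay, not a number (the limit of < 5000 nM in this assay, at which 1 of the 3 values shown sits). From it, the steps of an at least 22-fold lower number from compound 1 to compound 3 (1.34 log units; beyond the scatter) and an at least 40-fold lower number from compound 2 to compound 3 (1.60 log units; beyond the scatter) are large and beyond the scatter, marking the gap between a hydroxy on the carbonyl carbon and either ring substituent there.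

Compound 4, `Nc1ncc(-c2ccc(C(=O)N3CCC(O)CC3)cc2)nc1-c1ccc(C(F)(F)F)cc1`, is not yet measured. Its change from compound 1 is 4-hydroxypiperidin-1-yl in place of 3-hydroxyazetidin-1-yl on a carbonyl carbon. The step that bears on it is a 1.8-fold higher number from compound 1 to compound 2 (0.26 log units; within the scatter), where one ring substituent on the carbonyl carbon replaced another without a change beyond the scatter. In this assay no step beyond the scatter is therefore expected; the expected step is a 1.2-fold higher number from compound 1 to compound 4 (0.07 log units; within the scatter). Compound 4 is expected to give 130000 nM, between 50000 nM and 300000 nM.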

Compound 4, solubility: 119000 nM
Compound 4: middle estimate off by 1.1-fold (0.04 log units), on the high side; measured number inside the range.
By their numbers in this assay, from the lowest: compounds 1, 4 and 2 (each within the scatter of the next). At a limit, below all of these: compound 3.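

At the carbonyl carbon, the four-membered ring of 3-hydroxyazetidin-1-yl and the six-membered ring of 4-hydroxypiperidin-1-yl do not separate in this assay, the step being a 1.1-fold higher number from compound 1 to compound 4 (0.03 log units; within the scatter). With the ring held as six-membered, the earlier change of ring and substituent together now resolves into a single change on the saturated ring carbon, and hydroxy and amino do not separate either, the step being a 1.7-fold lower number from compound 2 to compound 4 (0.23 log units; within the scatter). Hydroxy directly on the carbonyl carbon stays apart from this ring as well, an at least 23-fold higher number from compound 3 to compound 4 (1.37 log units; beyond the scatter), a step that starts from a limit, not a number: the limit of < 5000 nM in this assay, at which 1 of the 4 values shown sits.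

Still open, as far as these compounds go, is whether the ring needs any substituent at all, as with plain piperidin-1-yl, or whether morpholin-4-yl reads alike. An open-chain amide, such as a hydroxyethyl amide, also remains to be placed in this assay.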